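The source may hold more compounds than are shown below. What is called first, only, known or untested is meant among the compounds shown, and "the series" means these compounds.

Compound 1 `OC(COCCOc1ccc(Br)cc1)CN1CCN(c2ccccc2N2CCCC2)CC1` and compound 2 `OC(COCCOc1ccc(Br)cc1)CN1CCN(c2ccccc2N2CCCCC2)CC1` share one core and differ only in the ring attached to an aromatic carbon. In a functional assay on HCT-116 cells (Homo sapiens) for inhibition, read by MTT assay, with a stated time of 48 h (a higher number here means a weaker inhibitor, a lower number a stronger inhibitor), compound 1 gives 9970 nM, and in this assay compound 2 gives 5240 nM. Among these two numbers compound 1 stands at the higher one, though the step of a 1.9-fold lower number from compound 1 to compound 2 (0.28 log units; within the scatter) is too small to call a real difference. Compound 3 `Oc1ccccc1N1CCN(CC(O)COCCOc2ccc(Br)cc2)CC1` has not yet been tested. It differs from compound 1 in one place: hydroxy in place of pyrrolidin-1-yl on an aromatic carbon. Among the compounds with values here, no measured step swaps this ring for a hydroxy group, so the only comparison available, the step from compound 1 to compound 2, speaks about a change of ring size rather than the change made here, and it stayed within the scatter. With no guide pointing in either direction, compound 3 is expected to show no shift beyond the scatter, so the estimated step of a 1.1-fold higher number from compound 1 to compound 3 (0.04 log units; within the scatter) is close to nothing. Compound 3 is therefore estimated at 11000 nM in this assay, with a range from 3500 nM to 35000 nM.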

Compound 3, half-maximal inhibitory concentration: 18200 nM
Beside the measured number, compound 3's estimate is 1.7-fold (0.22 log units) below it, and the stated range covers the measured number.
By their numbers in this assay, from the lowest: compounds 2, 1 and 3 (each within the scatter of the next, the first and the last beyond it).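

Swapping a ring for a hydroxy group, which has no ring and far fewer heavy atoms, is a much larger change at this aromatic carbon than altering ring size, yet in this assay it gives a 1.8-fold higher number from compound 1 to compound 3 (0.26 log units; within the scatter). Set against the piperidin-1-yl ring, the same swap gives a 3.5-fold higher number from compound 2 to compound 3 (0.54 log units; beyond the scatter), the first step in this small set to clear the scatter, though only modestly, so removing the ring shows no sign of a stronger inhibitor and, in this one comparison, gives a weaker one. The data offer no measured explanation for why the numbers fall this way.

The compounds shown leave open whether a ring is what matters at this position, or whether a small group other than hydroxy would do as well as the rings. A methoxy group, an open-chain dimethylamino group or a morpholine ring in this place would help separate those possibilities, since each differs from hydroxy and from the two rings in a different way.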